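A few compounds are considered here, and "the series" means these few. Any claim that something is new, unique, unknown or untested is made for them only; others in the source may bear on it.

Working notes on the series. In a functional assay on MGC-803 cells (Homo sapiens) for inhibition, read by sulforhodamine B assay (on this read-out higher numbers stand for weaker inhibition and lower numbers for stronger inhibition), compound 1 `O=C1C(Nc2ccccc2)=CC(=O)c2c1nc1n2[C@H]2OC[C@@H](O)[C@H]2OC1` gives 1830 nM, and compound 2 `Cc1ccc(NC2=CC(=O)c3c(nc4n3[C@H]3OC[C@@H](O)[C@H]3OC4)C2=O)cc1C` gives 1050 nM. Among the measured compounds shown here, these are the only two numbers available, and they lie within the scatter of each other, so compound 1 holds no distinct rank. Compound 3 `O=C1C=C(NC2CCCCC2)C(=O)c2c1nc1n2[C@H]2OC[C@@H](O)[C@H]2OC1`, which has no aromatic ring on the amine nitrogen, is reported only as a limit, > 8000 nM.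

The change to compound 4 `COc1ccccc1NC1=CC(=O)c2c(nc3n2[C@H]2OC[C@@H](O)[C@H]2OC3)C1=O` is methoxy in place of hydrogen on an aromatic carbon, which turns phenyl into 2-methoxyphenyl. For the measured compounds named here, the one measured step that alters this phenyl ring is a 1.7-fold lower number from compound 1 to compound 2 (0.24 log units; within the scatter), with 3,4-dimethylphenyl in place of phenyl, and it stays within the scatter. Going by the values given here, that step carries only limited weight, since no measured compound has a methoxy group. Among the compounds with values here, compound 3 offers no measured step for comparison. No step beyond the scatter is therefore expected in this assay, and the data favour no direction. The expected change is a 1.2-fold lower number from compound 1 to compound 4 (0.09 log units; within the scatter). For compound 4 the estimated value is 1500 nM, with an expected range of 600 nM to 4000 nM.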

Compound 4, half-maximal inhibitory concentration: 1670 nM
For compound 4 the middle estimate is 1.1-fold (0.05 log units) below the measured one; the range from low to high includes it.
By their numbers in this assay, from the lowest: compounds 2, 4 and 1 (each within the scatter of the next). At a limit, above all of these: compound 3.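

In this assay, among the compounds shown here, methoxy on an aromatic carbon, ortho to a large group, is the first oxygen-bearing substituent on this phenyl ring, and it gives a 1.1-fold lower number from compound 1 to compound 4 (0.04 log units; within the scatter). Exchanging the two substituted rings, 3,4-dimethylphenyl and 2-methoxyphenyl, gives a 1.6-fold higher number from compound 2 to compound 4 (0.20 log units; within the scatter), so this change also stays within the scatter. Together with the earlier step, a 1.7-fold lower number from compound 1 to compound 2 (0.24 log units; within the scatter), this places compounds 1, 2 and 4 in one group that cannot be separated, and the phenyl ring on the amine nitrogen carries either substitution without a step beyond the scatter in this small set.

For the compounds shown here, compound 3, the one member with cyclohexyl in place of an aromatic ring on the amine nitrogen, is reported only as a limit, so the series offers no sized step for that change: the limit of > 8000 nM in this assay, at which 1 of the 4 values shown sits. Still open, on these data alone, is whether a group of another kind on the phenyl ring, such as a carboxylic acid, a dimethylamino group or a nitrile, or methoxy at another ring carbon, would produce a step beyond the scatter in this assay.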